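The source may report more compounds than this note shows. Statements on the series, on what has been measured and on what is new or still open speak of the compounds shown alone.

Measured so far in a functional assay on NCI-H460 cells (Homo sapiens) for inhibition, read by MTT assay, with a stated time of 24 h, tested at 10 ug/mL; on this read-out lower numbers stand for less inhibition of growth and higher numbers for more inhibition of growth at the one concentration tested:
Compound 1 `O=C(CCCCC(S)CCS)Nc1ccccc1`: 8.37%
Compound 2 `O=C(CCCCC(S)CCS)Nc1cccc(Cl)c1`: "not active" (no number reported)
Compound 3 `O=C(CCCCC(S)CCS)Nc1cccc(C(F)(F)F)c1`: 11.4%

Going by the values given here, compound 3, at 11.4%, is one of only two compounds with a number, and the two numbers cannot be told apart: the measured step is a number 3 percentage points higher from compound 1 to compound 3 (within the scatter). Among the compounds with values here, compound 2 gives no number, so it provides no step.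

The next compound is compound 4 `Cc1cccc(NC(=O)CCCCC(S)CCS)c1`, which differs from compound 3 as follows: methyl in place of trifluoromethyl on an aromatic carbon. In words, this is methyl in place of trifluoromethyl on an aromatic carbon. Within the data shown here, no measured step exchanges these two groups. The nearest evidence is the step that installed trifluoromethyl in compound 3, a number 3 percentage points higher from compound 1 to compound 3 (within the scatter), and it is small. Nothing in the data therefore points to a real shift in either direction. The expected change is a number 2.4 percentage points lower from compound 3 to compound 4 (within the scatter), which amounts to no step beyond the scatter. The estimated value for compound 4 is 9%, with an expected range from 2% to 18%.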

Compound 4, percent growth inhibition at one concentration: 7.67%
Estimate against measurement, compound 4: 1.3 percentage points above, within the range that was stated.
By their numbers in this assay, from the lowest: compounds 4, 1 and 3 (each within the scatter of the next).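

At this aromatic carbon, methyl now joins hydrogen and trifluoromethyl, and in this assay the three cannot be told apart: the exchange of the two larger groups gives a number 3.7 percentage points lower from compound 3 to compound 4 (within the scatter), and adding methyl to the unsubstituted compound gives a number 0.7 percentage points lower from compound 1 to compound 4 (within the scatter). The earlier compounds shown here offered a single comparison at this carbon, whereas these steps show that the reading stays within the scatter across three different groups, with or without fluorine on the added carbon. No measurement available here explains this lack of separation.

As far as these compounds go, whether an amine or a carboxylic acid on this carbon would move the reading beyond the scatter remains open. Compound 2 has no number to compare, so the standing of chloro among these groups also remains unsettled.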